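A few compounds are considered here, and "the series" means these few. Any claim that something is new, unique, unknown or untested is made for them only; others in the source may bear on it.

Compound 1 `O=C(/C=C/c1cccnc1)NCCCCCCc1ccc(S(=O)(=O)Nc2ccccc2)cc1`: 328 nM
Compound 2 `O=C(/C=C/c1cccnc1)NCCCCCCc1cccc(S(=O)(=O)Nc2ccccc2)c1`: 6.73 nM
Compound 3 `Cc1ccc(NS(=O)(=O)c2cccc(CCCCCCNC(=O)/C=C/c3cccnc3)c2)cc1`: 34.4 nM

In a functional assay on DU-145 cells (Homo sapiens) for inhibition, read by CCK-8 assay, with a stated time of 72 h (a higher number here means a weaker inhibitor, a lower number a stronger inhibitor), compound 3 gives 34.4 nM, the second highest of the three numbers; its nearest neighbour is compound 2 and its furthest is compound 1. Among the measured compounds shown here, the one single-point step measured so far is a 5.1-fold higher number from compound 2 to compound 3 (0.71 log units; beyond the scatter), a methyl in place of hydrogen on an aromatic carbon.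

Compound 4 `Cc1ccccc1NS(=O)(=O)c1cccc(CCCCCCNC(=O)/C=C/c2cccnc2)c1` differs from compound 3 by 2-methylphenyl in place of 4-methylphenyl on a sulfonamide nitrogen. For the measured compounds named here, no measured step covers a change of this kind, so only the size of the nearby step is available as a guide. Compound 4 is therefore expected to show a 1.1-fold lower number from compound 3 to compound 4 (0.06 log units; within the scatter), a change not clearly beyond the scatter. The estimate for compound 4 in this assay is 30 nM, with a range from 10 nM to 100 nM.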

Compound 4, half-maximal inhibitory concentration: 2.9 nM
Estimate against measurement, compound 4: 10-fold (1.01 log units) above, and the stated range ends above it.
By their numbers in this assay, from the lowest: compound 4; then compound 2; then compound 3; then compound 1.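

Swapping 4-methylphenyl for 2-methylphenyl on the sulfonamide nitrogen changes no atom count, yet in this assay it gives (a 12-fold lower number from compound 3 to compound 4 (1.07 log units; beyond the scatter)). The effect of adding a methyl to the phenyl group therefore depends on where it sits, as the addition gives (a 5.1-fold higher number from compound 2 to compound 3 (0.71 log units; beyond the scatter)) in one case and (a 2.3-fold lower number from compound 2 to compound 4 (0.37 log units; beyond the scatter)) in the other. No evidence accounts for this difference.

From the compounds shown here alone, it remains open whether 2-methoxyphenyl or 2-chlorophenyl on the same nitrogen would follow 2-methylphenyl, and whether the effect holds with a shorter chain.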